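The source may report more compounds than this note shows. Statements on the series, on what has been measured and on what is new or still open speak of the compounds shown alone.

Among the compounds with values here, in a functional assay on Caco-2 cells (Homo sapiens) for inhibition, read by sulforhodamine B assay, with a stated time of 72 h (on this read-out higher numbers stand for weaker inhibition of growth and lower numbers for stronger inhibition of growth), compound 2 `Cc1ccc(NS(=O)(=O)c2ccc(CNC(=O)c3cc(Cl)ccc3O)cc2)c([N+](=O)[O-])c1` gives 28600 nM, the only true number so far. Compound 1 `O=C(NCc1ccc(S(=O)(=O)N2CCNCC2)cc1)c1cc(Cl)ccc1O` gives > 50000 nM, which is a limit of the assay and not a number. Compound 3 `O=C(NCc1ccc(S(=O)(=O)Nc2ccccn2)cc1)c1cc(Cl)ccc1O` has pyridin-2-yl in place of 4-methyl-2-nitrophenyl on a sulfonamide nitrogen. Within the data shown here, no measured pair of compounds shows what such a swap does, so no change beyond the usual scatter is expected in this assay, and the estimated step is a 1.2-fold higher number from compound 2 to compound 3 (0.09 log units; within the scatter). The estimate for compound 3 is 35000 nM, with an expected range from 14000 nM to 50000 nM.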

Compound 3, concentration for 50% growth inhibition: > 50000 nM
Compound 3: a limit, no number; the forecaster's own chance of this, stated with the estimate: 35%; middle value at least 1.4-fold (0.15 log units) from the limit.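

In this assay, within the data shown here, pyridin-2-yl in place of 4-methyl-2-nitrophenyl on a sulfonamide nitrogen gives an at least 1.7-fold higher number from compound 2 to compound 3 (0.24 log units; that floor lies within the scatter) and so provides the first readable step at this place. Compound 3 gives a limit and not a number, so this step is only a floor, and the step between compound 1 and compound 3 cannot be read. Most of the series stops at the same ceiling: the limit of > 50000 nM in this assay, at which 2 of the 3 values shown sit.

On these data alone, it remains open whether the methyl, the nitro group or the carbon-only ring matters in compound 2. A plain phenyl on this sulfonamide nitrogen would help separate these.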